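This account rests on a few compounds, and the source may have more. Where it says the series, first, only, none or still open, it means among the compounds named here.

Compound 1, `Clc1ccc(CN(Cc2nnn[nH]2)c2ccccc2)c(Cl)c1`, is a tetrazole carrying a tertiary amine substituted with a dichlorinated benzyl group and a plain phenyl ring. In a physicochemical assay for acid dissociation, compound 1 gives 4.54. Compound 2, `Cc1ccc(N(Cc2nnn[nH]2)Cc2ccc(Cl)cc2Cl)cc1`, differs from compound 1 in one place: methyl in place of hydrogen on an aromatic carbon. In this assay compound 2 gives 4.26, so that the change produced a number 0.28 log units lower from compound 1 to compound 2 (within the scatter).

Compound 3, `Fc1ccc(CN(Cc2nnn[nH]2)c2ccccc2)c(F)c1`, keeps the plain phenyl ring of compound 1 but carries fluorine in place of both chlorines on the benzyl group; how the two cores differ is not broken down here. In this assay compound 3 gives 4.13. The gap between compound 3 and compound 1 lies beyond the usual scatter, while the gap between compound 3 and compound 2 lies within it.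

Compound 4, `Cc1ccc(N(Cc2nnn[nH]2)Cc2ccc(F)cc2F)cc1`, has not yet been measured. It stands to compound 3 as compound 2 stands to compound 1: methyl in place of hydrogen on an aromatic carbon, the same change at the same place. Because the earlier step came out as a number 0.28 log units lower from compound 1 to compound 2 (within the scatter), a step of the same direction and size is expected here, namely a number 0.28 log units lower from compound 3 to compound 4 (within the scatter). On that basis compound 4 is estimated to give 3.85 in this assay, with the expected result lying between 3.55 and 4.15.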

Compound 4, acid dissociation constant: 4.23
Beside the measured number, compound 4's estimate is 0.38 log units below it, outside the stated range (above it).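

In this assay the new step reads a number 0.10 log units higher from compound 3 to compound 4 (within the scatter) and the earlier step on the other core reads a number 0.28 log units lower from compound 1 to compound 2 (within the scatter) so on both cores the change from phenyl to 4-methylphenyl stays inside what repeated measurements would show. Among the compounds shown here, what carries from one core to the other is therefore only that this change does not set the two compounds of either pair apart; the opposite signs of the two steps are no sign that the cores respond differently, and two pairs cannot show how the change would behave on a further core. No measurement is at hand that would account for either step.

The compounds shown leave open what happens when the methyl group is replaced by another group, such as a methoxy group, an amine or a carboxylic acid, and whether such a group would give a step beyond the scatter on both cores. They also leave open whether the comparison holds when the benzyl ring carries something other than chlorine or fluorine, such as a nitrile or a trifluoromethyl group.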